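Series notes: aryl swap from compound 3 to compound 4

The compounds below may be only part of what the source reports. "The series", "measured", "known", "first", "only" and "open" are said of these compounds alone.

Measured compounds:
compound 1 `CCOc1ccccc1N1CCN(CCCCn2ncc(=O)n(C)c2=O)CC1` gives 1.8 nM in an assay for displacement of a labelled ligand from Adrenergic receptor alpha-1 (Homo sapiens); a higher number here means a weaker inhibitor, a lower number a stronger inhibitor.
compound 2 `Cn1c(=O)cnn(CCCCN2CCN(c3ccccc3)CC2)c1=O` gives 64 nM in this assay.
compound 3 `Cn1c(=O)cnn(CCCCN2CCN(c3cccc(O)c3)CC2)c1=O` gives > 10000 nM in this assay, which is a limit of the assay and not a number (the limit of > 10000 nM in this assay, at which 1 of the 3 values shown sits).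

Compound 3 therefore stands at the weak end of the three, with only a limit known. The next compound, compound 4 `Cn1c(=O)cnn(CCCCN2CCN(c3ccccc3S)CC2)c1=O`, differs from it in one place: 2-sulfanylphenyl in place of 3-hydroxyphenyl on an amine nitrogen in a ring.

Among the measured compounds shown here, two measured steps bear on this change. Removing the ethoxy from compound 1 gave a 36-fold higher number from compound 1 to compound 2 (1.55 log units; beyond the scatter), and adding the hydroxy gave an at least 150-fold higher number from compound 2 to compound 3 (2.19 log units; beyond the scatter); together the change from the 2-ethoxyphenyl of compound 1 to the 3-hydroxyphenyl of compound 3 gave an at least 5500-fold higher number from compound 1 to compound 3 (3.74 log units; beyond the scatter). Compound 4 carries a 2-sulfanylphenyl, so it gives up the hydroxy that accompanied the large loss and takes on a group named in the same manner as the 2-ethoxyphenyl of compound 1, though with sulfur in place of the ethoxy oxygen. A large step back toward stronger binding is therefore expected, of about an at least 330-fold lower number from compound 3 to compound 4 (2.52 log units; beyond the scatter) in this assay. For compound 4 the estimated value is 30 nM, with a range from 5 nM to 300 nM.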

Compound 4, inhibition constant: > 10000 nM
Compound 4: no number, only a limit (the forecaster's own chance of this, stated with the estimate: 5%); middle value at least 330-fold (2.52 log units) away from the limit.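

In this assay compound 4 gives > 10000 nM, which is a limit of the assay and not a number, and it joins compound 3 at that limit: the limit of > 10000 nM in this assay, at which 2 of the 4 values shown sit.

Sulfanyl in place of hydrogen on an aromatic carbon gave an at least 150-fold higher number from compound 2 to compound 4 (2.19 log units; beyond the scatter), and sulfanyl in place of ethoxy gave an at least 5500-fold higher number from compound 1 to compound 4 (3.74 log units; beyond the scatter). The earlier compounds shown here linked a large loss only to the hydroxy of compound 3; compound 4 shows a large loss with a different group, so a 2-substituted phenyl does not by that alone keep the strong binding of compound 1.

The step between compound 3 and compound 4 cannot be read, as both values are limits, and the 2-sulfanylphenyl and 3-hydroxyphenyl therefore remain unranked against each other. Also open, going by these compounds, is what a methoxy, a methylsulfanyl or an ethylsulfanyl would give on the aromatic carbon that bears the ethoxy in compound 1, which would separate the effect of the sulfur from that of the attached ethyl chain.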